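The source may hold more compounds than are shown below. What is called first, only, known or untested is meant among the compounds shown, and "the series" means these compounds.

Measured so far in a functional assay on NCI-H522 cells (Homo sapiens) for inhibition, read by sulforhodamine B assay, with a stated time of 48 h; a lower number here means a stronger inhibitor of growth, a higher number a weaker inhibitor of growth:

Compound 1 `Nc1cc(N)c2nc(-c3ccccc3)c(Oc3ccc(F)cc3)nc2c1`: < 100000 nM
Compound 2 `COc1cc(CNc2nc3cc(N)cc(N)c3nc2-c2ccccc2)cc(OC)c1OC`: < 50200 nM
Compound 3 `Nc1cc(N)c2nc(-c3ccccc3)c(Sc3ccc(Cl)c(Cl)c3)nc2c1`: 33900 nM

Of these, the value of compound 1 in this assay is a limit of the assay, not a number. The value of compound 2 is likewise a limit. Going by the values given here, compound 3 gives the only number in the set, 33900 nM. The two further values stand as limits, so no ranking against compound 3 can be read from them.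

Compound 4 `COc1ccc(Sc2nc3cc(N)cc(N)c3nc2-c2ccccc2)cc1` is not yet measured. The change from compound 3 is 4-methoxyphenyl in place of 3,4-dichlorophenyl on a sulfur.

Among the compounds with values here, only one measured step in this assay exists, a step that the limit leaves unreadable from compound 1 to compound 3, and its size cannot be read because the limit of < 100000 nM in this assay, at which 1 of the 3 values shown sits, caps compound 1. Within the data shown here, no readable step therefore bears on the move to compound 4, and the change of substituent on the sulfur has no measured precedent here. The working expectation is no step beyond the scatter. The expected step is a 1.2-fold higher number from compound 3 to compound 4 (0.07 log units; within the scatter). Compound 4 is thus estimated at 40000 nM, with a range of 12000 nM to 130000 nM.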

Compound 4, concentration for total growth inhibition: < 100000 nM
Compound 4: a limit, no number; the forecaster's own chance of this, stated with the estimate: 40%; the middle value is on the limit's open side.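

In this assay compound 4 gives < 100000 nM, a limit and not a number. The steps from compound 3 to compound 4 and from compound 1 to compound 4 therefore cannot be read. On these data alone, whether 4-methoxyphenyl or 3,4-dichlorophenyl on the sulfur gives the stronger inhibitor of growth remains open.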